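A few compounds are considered here, and "the series" means these few. Any claim that something is new, unique, unknown or untested is made for them only; others in the source may bear on it.

Working notes on the series.

The shared core is carried by compound 1 `Nc1nccn2cc(-c3ccccc3)nc12`, which in an assay on cells for displacement of a labelled ligand from transmembrane domain-containing protein TMIGD3 (Homo sapiens), read by scintillation counting, with a stated time of 120 min, tested at 1 uM (a higher number here means more inhibition at the concentration tested (going by the name of the read-out), a lower number less inhibition), gives 12%. Compound 2 `Nc1nc(-c2ccccc2)cn2cc(-c3ccccc3)nc12` adds phenyl in place of hydrogen on an aromatic carbon; in this assay compound 2 gives 23%, and the step of a number 11 percentage points higher from compound 1 to compound 2 (beyond the scatter) lies beyond the scatter. Within the data shown here, compound 2 therefore stands highest of the two numbers so far, with compound 1 as its only neighbour.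

Compound 3 `COc1ccc(-c2cn3cc(-c4ccccc4)nc3c(N)n2)cc1` is to be measured next. It differs from compound 2 by methoxy in place of hydrogen on an aromatic carbon, a small group on the outer six-membered aromatic ring of carbon only. Among the measured compounds shown here, the one measured step, that from compound 1 to compound 2, concerns a whole phenyl entering and does not speak directly to a methoxy added to that phenyl. For the measured compounds named here, no step of this kind exists, so the expected step of a number 5 percentage points higher from compound 2 to compound 3 (within the scatter) is small, possibly within the scatter, with a slight lean upward. Compound 3 is estimated at 28%, between 10% and 48%.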

Compound 3, a percentage reported as inhibition, at one concentration (the size of the read-out at that concentration, not a potency): 23%
Compound 3: middle estimate off by 5 percentage points, on the high side; the measured number falls inside the stated range.
By their numbers in this assay, from the lowest: compound 1; then compounds 2 and 3 (each within the scatter of the next).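

In this assay methoxy on an aromatic carbon, para to a large group, gives no change at the digits printed from compound 2 to compound 3 (within the scatter), so this position on the added phenyl accepts the change from phenyl to 4-methoxyphenyl with no shift that can be told from the scatter. Set against the shared core, 4-methoxyphenyl in place of hydrogen on an aromatic carbon gives a number 11 percentage points higher from compound 1 to compound 3 (beyond the scatter), which shows that the gain over compound 1 persists with the larger group. Nothing on hand explains either step.

Still open, on these data alone, is whether a group other than methoxy at this same place, such as an amine or a carboxylic acid, would move the number beyond the scatter. The compounds shown also leave open what a longer chain such as butoxy would do there.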